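Azetidine in Place of a Fluoropyridine on the Core

A few compounds are considered here, and "the series" means these few. Any claim that something is new, unique, unknown or untested is made for them only; others in the source may bear on it.

Measured compounds:
Compound 1 `COc1ccc(CNC(=O)c2cc(-c3cncc(C)c3)ncc2-c2cncc(F)c2)nc1OC`: 57 nM
Compound 2 `COc1ccc(CNC(=O)c2nc(-c3cncc(C)c3)ncc2-c2ccccc2)nc1OC`: 120 nM

In an assay on CHO cells for antagonist activity at Orexin receptor type 2 (Homo sapiens), read by FLIPR, with a stated time of 5 min (a lower number here means a stronger inhibitor, a higher number a weaker inhibitor), compound 1 gives 57 nM and stands with the lowest of the two numbers shown; compound 2 gives 120 nM, a number beyond the scatter above it. Compound 3 `COc1ccc(CNC(=O)c2cc(-c3cncc(C)c3)ncc2N2CCC2)nc1OC` has not been measured. It differs from compound 1 in one place: azetidin-1-yl in place of 5-fluoropyridin-3-yl on an aromatic carbon. For the measured compounds named here, no step between measured compounds speaks to this change, so the expected size rests on the structures alone. Compound 3 is expected to give a weaker result, a step of a 3.5-fold higher number from compound 1 to compound 3 (0.55 log units; beyond the scatter) in this assay, with an estimated value of 200 nM in a range from 60 nM to 700 nM.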

Compound 3, half-maximal inhibitory concentration: 83 nM
Compound 3: middle estimate off by 2.4-fold (0.38 log units), on the high side; low and high end bracket the measured number.
By their numbers in this assay, from the lowest: compounds 1, 3 and 2 (each within the scatter of the next, the first and the last beyond it).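

In this assay, azetidin-1-yl in place of 5-fluoropyridin-3-yl gives a 1.5-fold higher number from compound 1 to compound 3 (0.16 log units; within the scatter). At this position, ortho to a large group, a four-membered non-aromatic ring with fewer heavy atoms therefore reads the same as the six-membered aromatic ring, so an aromatic ring is not required here to keep the number in this range. No measurement offered here explains this result.

Going by these compounds, it remains open whether larger saturated rings such as pyrrolidine or morpholine, or an open-chain dimethylamino group, would hold the number in the same range.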